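Swapping the Aryl Group: A Modest Change in Cell Inhibition Expected

The source may hold more compounds than are shown below. What is called first, only, known or untested is meant among the compounds shown, and "the series" means these compounds.

Measured so far:
compound 1 `Cc1ccc(-n2cc(COc3ccc4c(c3)CCC4)nn2)c(C)c1`: 19.9%
compound 2 `COc1cccc(NC(=O)Cn2cc(COc3ccc4c(c3)CCC4)nn2)c1`: "not determined" (no result reported)

For the measured compounds named here, compound 1 is the only compound with a number in an ADME assay on HEK293 cells (Homo sapiens) for inhibition, read by MTT assay, with a stated time of 48 h, tested at 25 uM; a higher number here means more inhibition at the concentration tested (going by the name of the read-out), a lower number less inhibition; in that assay compound 1 gives 19.9%, a low percentage. Compound 2 was entered but came back as "not determined" (no result reported), so no comparison between two measured compounds is available. Compound 3 `COc1ccc(-n2cc(COc3ccc4c(c3)CCC4)nn2)cc1` has not been measured; its difference from compound 1 is 4-methoxyphenyl in place of 2,4-dimethylphenyl on an aromatic nitrogen. Going by the values given here, with no measured pair to learn from, the step is expected to stay within the usual scatter, in either direction. Compound 3 is therefore estimated at 18%, with a range from 5% to 35%, which means an expected step of a number 1.9 percentage points lower from compound 1 to compound 3 (within the scatter).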

Compound 3, a percentage reported as inhibition, at one concentration (the size of the read-out at that concentration, not a potency): 21.1%
The estimate for compound 3 lay 3.1 percentage points below the measured number; measured number inside the range.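

In this assay, for the compounds shown here, putting 4-methoxyphenyl in place of 2,4-dimethylphenyl on an aromatic nitrogen gives a number 1.2 percentage points higher from compound 1 to compound 3 (within the scatter), the first step that can be read at this position. At this one concentration, the two methyl groups can therefore give way to a single methoxy group without moving the read-out beyond the scatter. No supporting data bear on why this exchange leaves the read-out within the scatter.

Still open, as far as these compounds go, is whether a phenyl ring carrying an amine or a carboxylic acid would behave the same way. A longer chain between this nitrogen and the ring is equally unresolved.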